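Leaving the 3-hydroxy-4-nitrophenyl Group: Compound 3 to Compound 4

This account rests on a few compounds, and the source may have more. Where it says the series, first, only, none or still open, it means among the compounds named here.

In a functional assay on DU-145 cells (Homo sapiens) for inhibition, read by trypan blue exclusion, with a stated time of 96 h (a higher number here means a weaker inhibitor of growth, a lower number a stronger inhibitor of growth), compound 3 `O=C(O)c1ccc(C(=O)/C(=C\c2ccc([N+](=O)[O-])c(O)c2)SCc2ccc(Br)cc2)cc1` gives 10000 nM, the highest of the three numbers, while compound 1 `CN(C)c1ccc(/C=C(/SCc2ccc(Cl)cc2)C(=O)c2ccc(C(=O)O)cc2)cc1` gives 1000 nM and compound 2 `COc1cc(/C=C(/SCc2ccc(Br)cc2)C(=O)c2ccc(C(=O)O)cc2)ccc1F` gives 1000 nM. Compound 4 `CN(C)c1ccc(/C=C(/SCc2ccc(Br)cc2)C(=O)c2ccc(C(=O)O)cc2)cc1` awaits measurement and differs from compound 3 as follows: 4-(dimethylamino)phenyl in place of 3-hydroxy-4-nitrophenyl on a double-bonded chain carbon bound to a double-bonded chain carbon. Among the compounds with values here, one measured step bears directly on this change: a 10-fold higher number from compound 2 to compound 3 (1.00 log units; beyond the scatter), in which the 3-hydroxy-4-nitrophenyl group entered. Compound 1 also carries the 4-(dimethylamino)phenyl group, and its 1000 nM points the same way. A step of similar size towards a lower number is therefore expected in this assay. The estimated change is a 10-fold lower number from compound 3 to compound 4 (1.00 log units; beyond the scatter). For compound 4 the expected value is 1000 nM, with an estimated range of 300 nM to 3500 nM.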

Compound 4, concentration for 50% growth inhibition: 50000 nM
For compound 4 the middle estimate is 50-fold (1.70 log units) below the measured one, and the stated range ends below it.
By their numbers in this assay, from the lowest: compounds 1 and 2 (each within the scatter of the next); then compound 3; then compound 4.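

In this assay the 4-(dimethylamino)phenyl group on this double-bonded chain carbon gave a 5.0-fold higher number from compound 3 to compound 4 (0.70 log units; beyond the scatter) and a 50-fold higher number from compound 2 to compound 4 (1.70 log units; beyond the scatter) so, with bromo on the aromatic carbon, this group stands at the high end of the compounds shown. Compound 1 did not carry over to it: bromo in place of chloro on an aromatic carbon gave a 50-fold higher number from compound 1 to compound 4 (1.70 log units; beyond the scatter) and so the reading for this aryl group changed with the halogen. Nothing at hand explains these steps.

From the compounds shown here alone, whether chloro would give a similar step alongside the 4-fluoro-3-methoxyphenyl or 3-hydroxy-4-nitrophenyl group stays open. So does how a primary amine in place of the dimethylamino group would read.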